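The source may report more compounds than this note shows. Statements on the series, on what has been measured and on what is new or still open speak of the compounds shown alone.

Measured in a functional assay on MDA-MB-435 cells (Homo sapiens) for inhibition, read by sulforhodamine B assay, with a stated time of 48 h; on this read-out lower numbers stand for stronger inhibition of growth and higher numbers for weaker inhibition of growth:
compound 1 `O=C(Nc1cccc(-n2cc(-c3ccncc3)c(-c3ccc(Cl)c(O)c3)n2)c1)Nc1ccc(Cl)c(Cl)c1`, 6050 nM;
compound 2 `COc1cc(-c2nn(-c3cccc(NC(=O)c4ccc(Cl)c(C(F)(F)F)c4)c3)cc2-c2ccncc2)ccc1Cl`, 1740 nM.

Of these two numbers compound 2 holds the lower one, and its gap to compound 1 lies beyond the usual scatter. Compound 3 `COc1cc(-c2nn(-c3cccc(NC(=O)c4cccc(C(F)(F)F)c4)c3)cc2-c2ccncc2)ccc1Cl` has not yet been measured in this assay. It differs from compound 2 by hydrogen in place of chloro on an aromatic carbon, on an aromatic carbon of a six-membered aromatic ring of carbon only, ortho to a trifluoromethyl group and para to a large group. Going by the values given here, no step of this kind exists among the measured compounds, so the expected step of a 1.7-fold higher number from compound 2 to compound 3 (0.24 log units; within the scatter) is a small weakening, within the scatter. Compound 3 is therefore estimated at 3000 nM, between 1200 nM and 8000 nM.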

Compound 3, concentration for total growth inhibition: 1770 nM
Compound 3: the middle estimate sits 1.7-fold (0.23 log units) above what was measured; the measured number falls inside the stated range.
By their numbers in this assay, from the lowest: compounds 2 and 3 (each within the scatter of the next); then compound 1.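

In this assay, hydrogen in place of chloro, which turns 4-chloro-3-(trifluoromethyl)phenyl into 3-(trifluoromethyl)phenyl, gives a 1.0-fold higher number from compound 2 to compound 3 (0.01 log units; within the scatter), so at this position the two cannot be told apart. The earlier compounds shown here held no step at this place; this one shows that compound 2 does not depend on its chloro for its level of growth inhibition. No measurement at hand explains this result. Going by these compounds, whether an amine or a carboxylic acid at this position would read the same stays open, as does the effect of taking away the trifluoromethyl group.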